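This account rests on a few compounds, and the source may have more. Where it says the series, first, only, none or still open, it means among the compounds named here.

In an ADME assay on the whole organism (Rattus norvegicus, strain Sprague-Dawley) for pharmacokinetics, read by LC-MS, with a stated time of 48 h, at a dose of 5 mg/kg by the intravenous route (on this read-out lower numbers stand for slow clearance and higher numbers for fast clearance), compound 1 `CC#CCn1c(N2CCC[C@@H](N)C2)nc2c1c(=O)n(Cc1ccc(Br)cc1C(=O)O)c(=O)n2C` gives 3.67 mL/min/kg with its 4-bromo-2-carboxyphenyl group and compound 2 `CC#CCn1c(N2CCC[C@@H](N)C2)nc2c1c(=O)n(Cc1cc(OC)ccc1C(=O)O)c(=O)n2C` gives 21.7 mL/min/kg with its 2-carboxy-5-methoxyphenyl group, so compound 2 holds the higher of the two numbers. For the measured compounds named here, the only measured step is a 5.9-fold higher number from compound 1 to compound 2 (0.77 log units; beyond the scatter) and it lies beyond the scatter.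

Next is compound 3 `CC#CCn1c(N2CCC[C@@H](N)C2)nc2c1c(=O)n(Cc1ccc(Cl)cc1C(=O)O)c(=O)n2C`, with the change 2-carboxy-4-chlorophenyl in place of 2-carboxy-5-methoxyphenyl on a saturated chain carbon bound to an aromatic nitrogen and in words 2-carboxy-4-chlorophenyl in place of 2-carboxy-5-methoxyphenyl on a saturated chain carbon bound to an aromatic nitrogen. The entering group differs from the 4-bromo-2-carboxyphenyl group of compound 1 only in chlorine for bromine. Going by the values given here, no measured compound yet carries chlorine, so the evidence is a single pair. The expectation therefore leans on compound 1 at 3.67 mL/min/kg and runs the measured step backwards, towards a lower number. An estimated 4.3-fold lower number from compound 2 to compound 3 (0.64 log units; beyond the scatter) is expected in this assay and should lie beyond the scatter. The number expected for compound 3 is 5 mL/min/kg with an estimated range from 2.5 mL/min/kg to 11 mL/min/kg in this read-out.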

Compound 3, clearance: 8.83 mL/min/kg
Compound 3: the middle estimate sits 1.8-fold (0.25 log units) below what was measured, and the stated range covers the measured number.
By their numbers in this assay, from the lowest: compound 1; then compound 3; then compound 2.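

In this assay, for the compounds shown here, chloro in place of bromo on an aromatic carbon is the first change confined to a single atom, and it gives a 2.4-fold higher number from compound 1 to compound 3 (0.38 log units; beyond the scatter); the two halogens are therefore not interchangeable on this read-out, with bromo giving the lower number. The step of a 2.5-fold lower number from compound 2 to compound 3 (0.39 log units; beyond the scatter) adds a second comparison with the 2-carboxy-5-methoxyphenyl group, so both halogen-bearing groups now give lower numbers than that group, and none of the three compounds goes against this order. No measurement on hand bears on what lies behind either step.

The compounds shown leave open whether the gap between the halogens and methoxy belongs to the groups themselves or to where they stand on the ring, as the group names place them differently. Also open, on these data alone, are whether a fluoro or a methyl group on the same aromatic carbon would extend the order seen with chloro and bromo, and how an amide in place of the carboxylic acid would read in this assay.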